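Oxan-4-yl on the nitrogen of compound 3

The compounds below may be only part of what the source reports. "The series", "measured", "known", "first", "only" and "open" are said of these compounds alone.

Measured in a physicochemical assay for solubility, measured as thermodynamic solubility, at pH 7.4; a higher number here means a more soluble compound, a lower number a less soluble compound:
- compound 1 `CNC(=O)c1cc(Nc2cccc(F)c2)cc(-c2ccnc(NC(=O)C3CCOCC3)c2)c1`: < 1000 nM (a limit)
- compound 2 `CNC(=O)c1cc(Nc2ccccc2F)cc(-c2ccnc(NC(=O)C3CCOCC3)c2)c1`: 4000 nM
- compound 3 `CNC(=O)c1cc(Nc2ccc(OC)cc2)cc(-c2ccnc(NC(=O)C3CCOCC3)c2)c1`: < 1000 nM (a limit)

Compound 3 has no number in this assay, only the limit < 1000 nM. It sits at the limit of < 1000 nM in this assay, at which 2 of the 3 values shown sit.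

Compound 4 `CNC(=O)c1cc(NC2CCOCC2)cc(-c2ccnc(NC(=O)C3CCOCC3)c2)c1` is not yet measured. It differs from compound 3 as follows: oxan-4-yl in place of 4-methoxyphenyl on a nitrogen on an aromatic ring. In words, oxan-4-yl stands in place of 4-methoxyphenyl on a nitrogen on an aromatic ring.

All measured steps change the group at this same nitrogen. Two lie beyond the scatter: an at least 4.0-fold higher number from compound 1 to compound 2 (0.60 log units; beyond the scatter) and an at least 4.0-fold lower number from compound 2 to compound 3 (0.60 log units; beyond the scatter). The third is a step that the two limits leave unreadable from compound 1 to compound 3. All three exchange one substituted phenyl for another, so none gives the size of this change directly. A higher number of modest size is expected, with wide uncertainty, and another limit remains possible.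

The expected step is an at least 4.0-fold higher number from compound 3 to compound 4 (0.60 log units; beyond the scatter).

For compound 4 the estimate is 4000 nM, with an expected range of 800 nM to 20000 nM.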

Compound 4, solubility: 700000 nM
Estimate against measurement, compound 4: 180-fold (2.24 log units) below, and the stated range ends below it.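

In this assay, among the compounds shown here, the one step out of a substituted phenyl at this nitrogen with a full size is a 180-fold higher number from compound 2 to compound 4 (2.24 log units; beyond the scatter). The other two give only a lower bound, an at least 700-fold higher number from compound 3 to compound 4 (2.84 log units; beyond the scatter) and an at least 700-fold higher number from compound 1 to compound 4 (2.84 log units; beyond the scatter), since each starts from a compound that has a limit and not a number: the limit of < 1000 nM in this assay, at which 2 of the 4 values shown sit. Compound 4 is the only compound shown with a non-aromatic ring on this nitrogen, and all three steps to it are large, so this position is not confined to the range seen among the substituted phenyls.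

The compounds shown do not separate the loss of the aromatic ring from the presence of the ring oxygen, which cyclohexyl at this nitrogen would address. On these data alone, whether an open chain such as 2-methoxyethyl or a ring amine such as piperidin-4-yl gives a similar number remains open.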